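Methyl on the benzyl ring of a sigma-1 ligand

The source may hold more compounds than are shown below. What is called first, only, known or untested is meant among the compounds shown, and "the series" means these compounds.

Measured compounds in an assay on membranes from liver for displacement of a labelled ligand from Sigma non-opioid intracellular receptor 1 (Rattus norvegicus), read by scintillation counting; a lower number here means a stronger inhibitor, a higher number a weaker inhibitor:
compound 1, `CN(CCCn1c(=O)oc2ccccc21)Cc1ccccc1`, gives 223 nM;
compound 2, `Cc1cccc(CN(C)CCCn2c(=O)oc3ccccc32)c1`, gives 1840 nM;
compound 3, `O=C(Nc1ccccc1)C1CCN(Cc2ccccc2)CC1`, gives 48.1 nM.

Compound 1 and compound 2 share a core and differ by methyl in place of hydrogen on an aromatic carbon; this change brought an 8.3-fold higher number from compound 1 to compound 2 (0.92 log units; beyond the scatter). Compound 3 has a different core, and the difference between the two cores is not broken down here. Compound 4, `Cc1ccc(CN2CCC(C(=O)Nc3ccccc3)CC2)cc1`, is not yet measured; it differs from compound 3 by methyl in place of hydrogen on an aromatic carbon. The added group sits para to a large group in compound 4 but meta to a large group in compound 2, so the change is the same kind of change, not the same. Among the compounds with values here, on the one measured example, the step from compound 3 to compound 4 is expected to be a 4.2-fold higher number from compound 3 to compound 4 (0.62 log units; beyond the scatter), giving an estimated 200 nM for compound 4 in this assay, with a likely range from 60 nM to 700 nM.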

Compound 4, inhibition constant: 105 nM
For compound 4 the middle estimate is 1.9-fold (0.28 log units) above the measured one; low and high end bracket the measured number.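

In this assay the added methyl again gave a weaker inhibitor on the second core (a 2.2-fold higher number from compound 3 to compound 4 (0.34 log units; beyond the scatter)), so the direction of the change held on both cores. The size of the step did not carry over from one core to the other: the same change on two cores in this assay, an 8.3-fold higher number (0.92 log units; beyond the scatter) from compound 1 to compound 2 and a 2.2-fold higher number (0.34 log units; beyond the scatter) from compound 3 to compound 4, 3.8-fold (0.58 log units) apart, beyond the scatter of two such steps. With only these two steps, the effect of changing the core cannot be separated from that of the methyl's different place on the ring, and two cores cannot show a rule for the whole series.

The compounds shown leave open how large the step would be with the methyl in the same place on both cores. They also leave open whether an ethyl or methoxy group on that ring would shift the number in the same direction.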